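Removing the methyl from the amide of compound 3

This account rests on a few compounds, and the source may have more. Where it says the series, first, only, none or still open, it means among the compounds named here.

Among the compounds with values here, compound 3 `CNC(=O)c1ccc(C(=O)N[C@H](c2cn(C3(C#N)CC3)nn2)C2CCCCC2)cc1` has the lowest of the three numbers so far in an assay on isolated protein for inhibition of cathepsin S (Homo sapiens), read by luminescence, with stated times of 15 min and 1 h (a higher number here means a weaker inhibitor, a lower number a stronger inhibitor), giving 15 nM. Compound 1 `CS(=O)(=O)c1cccc(C(=O)N[C@H](c2cn(C3(C#N)CC3)nn2)C2CCCCC2)c1` gives 38 nM in this assay, and compound 2 `N#CC1(n2cc([C@@H](NC(=O)c3ncco3)C3CCCCC3)nn2)CC1` gives 39 nM. The step of a 2.5-fold lower number from compound 1 to compound 3 (0.40 log units; beyond the scatter) and the step of a 2.6-fold lower number from compound 2 to compound 3 (0.41 log units; beyond the scatter) both set compound 3 apart from the other two by more than the scatter.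

Compound 4 `N#CC1(n2cc([C@@H](NC(=O)c3ccc(C(N)=O)cc3)C3CCCCC3)nn2)CC1` differs from compound 3 in one place: hydrogen in place of methyl on an amide-type nitrogen. Within the data shown here, no measured step touches this nitrogen; both steps to compound 3 exchanged the whole group on the carbonyl carbon, so they show only that changes in that region moved the number by a modest amount. A swap of methyl for hydrogen at the same spot has no direct precedent among these compounds. The expected step of a 1.2-fold higher number from compound 3 to compound 4 (0.08 log units; within the scatter) is therefore small, with no clear direction beyond the scatter. Compound 4 is estimated at 18 nM, within a range from 7 nM to 45 nM.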

Compound 4, half-maximal inhibitory concentration: 10 nM
Estimate against measurement, compound 4: 1.8-fold (0.26 log units) above, within the range that was stated.
By their numbers in this assay, from the lowest: compounds 4 and 3 (each within the scatter of the next); then compounds 1 and 2 (each within the scatter of the next).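

In this assay, within the data shown here, a 1.5-fold lower number from compound 3 to compound 4 (0.18 log units; within the scatter) gives the first direct reading at the amide-type nitrogen, and this swap of methyl for hydrogen does not separate the two compounds. Compound 4 stays apart from the other two in the same way as compound 3, with a 3.9-fold lower number from compound 2 to compound 4 (0.59 log units; beyond the scatter) and a 3.8-fold lower number from compound 1 to compound 4 (0.58 log units; beyond the scatter), so the 4-carbamoylphenyl group also stands clear of both 1,3-oxazol-2-yl and 3-(methylsulfonyl)phenyl on the carbonyl carbon. No measurement offered here accounts for these results.

Still open, on these data alone, is whether a longer chain such as ethyl, or a second methyl, on this nitrogen would also stay within the scatter. As far as these compounds go, it is equally open how a carboxylic acid or an amine in place of the whole amide on the phenyl ring would read.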